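Anilide substitution on the shared core: cytotoxicity notes

The source may report more compounds than this note shows. Statements on the series, on what has been measured and on what is new or still open speak of the compounds shown alone.

Measured in a functional assay on A549 cells (Homo sapiens) for cytotoxicity, read by MTT assay, with a stated time of 48 h (on this read-out higher numbers stand for an effect only at larger amounts of compound and lower numbers for an effect already at smaller amounts), so far:
compound 1 `Cc1ccc(NC(=O)CN2C(=O)/C(=N\NC(=O)Cn3ccc(=O)c(O)c3C)c3ccccc32)cc1` gives 47500 nM
compound 2 `Cc1c(O)c(=O)ccn1CC(=O)N/N=C1\C(=O)N(CC(=O)Nc2ccccc2)c2ccccc21` gives 29200 nM
compound 3 `CC(=O)Nc1ccc(NC(=O)CN2C(=O)/C(=N\NC(=O)Cn3ccc(=O)c(O)c3C)c3ccccc32)cc1` gives only a limit, > 100000 nM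

Compound 2 holds the lowest of the two numbers; its nearest neighbour is compound 1, and the step of a 1.6-fold lower number from compound 1 to compound 2 (0.21 log units; within the scatter) lies within the scatter. Compound 3 sits at a limit of this assay (the limit of > 100000 nM in this assay, at which 1 of the 3 values shown sits). The steps of an at least 2.1-fold higher number from compound 1 to compound 3 (0.32 log units; beyond the scatter) and an at least 3.4-fold higher number from compound 2 to compound 3 (0.53 log units; beyond the scatter) go beyond the scatter.

Compound 4 `Cc1cccc(NC(=O)CN2C(=O)/C(=N\NC(=O)Cn3ccc(=O)c(O)c3C)c3ccccc32)c1C` differs from compound 2 by 2,3-dimethylphenyl in place of phenyl on an amide-type nitrogen. Only the methyl step from compound 1 to compound 2 bears on this change, and it stayed within the scatter; the acetamido steps concern another group. For compound 4 no step beyond the scatter is therefore expected, a 1.2-fold higher number from compound 2 to compound 4 (0.08 log units; within the scatter). The estimate for compound 4 is 35000 nM, between 12000 nM and 100000 nM.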

Compound 4, half-maximal effective concentration: 39200 nM
For compound 4 the middle estimate is 1.1-fold (0.05 log units) below the measured one, and the stated range covers the measured number.
By their numbers in this assay, from the lowest: compounds 2, 4 and 1 (each within the scatter of the next). At a limit, above all of these: compound 3.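

In this assay the 2,3-dimethylphenyl group on the amide-type nitrogen cannot be told apart from phenyl or 4-methylphenyl, with a 1.3-fold higher number from compound 2 to compound 4 (0.13 log units; within the scatter) and a 1.2-fold lower number from compound 1 to compound 4 (0.08 log units; within the scatter), so methyl substitution on this ring has so far moved nothing beyond the scatter. Only 4-acetamidophenyl separates from this group, with an at least 2.5-fold lower number from compound 3 to compound 4 (0.40 log units; beyond the scatter). The value of compound 3 is a limit, not a number: the limit of > 100000 nM in this assay, at which 1 of the 4 values shown sits.

Open, from the compounds shown here alone, is whether 4-aminophenyl or 4-carboxyphenyl on the same nitrogen would separate as 4-acetamidophenyl does. Also open, going by these compounds, is whether a longer chain, such as 4-butylphenyl, would stay with the methyl-substituted compounds.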